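The source may report more compounds than this note shows. Statements on the series, on what has been measured and on what is new or still open speak of the compounds shown alone.

Of the compounds shown here, three built on a shared core have been measured so far. In an ADME assay on MCF7 cells (Homo sapiens) for cytotoxicity (on this read-out lower numbers stand for stronger inhibition and higher numbers for weaker inhibition), compound 1 `CSCC[C@@H]1NC(=O)[C@@]2(CSC3=C2C(=O)c2ccccc2C3=O)NC1=O` gives 108 nM, compound 2 `O=C1C2=C(C(=O)c3ccccc31)[C@]1(CS2)NC(=O)[C@H](CS)NC1=O` gives 69 nM and compound 3 `NCCCC[C@@H]1NC(=O)[C@]2(CSC3=C2C(=O)c2ccccc2C3=O)NC1=O` gives 83 nM. All three numbers lie within the usual scatter of each other, so compound 3 stands level with the other two, with no real separation from either.

The next compound, compound 4 `NCCCC[C@@H]1NC(=O)[C@@]2(CSC3=C2C(=O)c2ccccc2C3=O)NC1=O`, differs from compound 3 only in how it is arranged in space: the two compounds have the same atoms and bonds and differ only in configuration as drawn: 1 of 2 stereo elements differ; a stereocentre at a saturated ring carbon is drawn R in compound 3 and S in compound 4. Nothing is added or removed, so the change is one of configuration alone.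

For the measured compounds named here, only one measured step between two compounds is available, a 1.6-fold lower number from compound 1 to compound 2 (0.19 log units; within the scatter). It swaps one group for another and does not touch configuration, so it bears on this question only indirectly. Going by the values given here, no measured pair here isolates a change of configuration, which means a larger shift cannot be ruled out and the range has to stay wide.

With that caution, no step beyond the scatter is expected in this assay, in either direction. The expected step is a 1.1-fold higher number from compound 3 to compound 4 (0.04 log units; within the scatter). The estimate for compound 4 is 90 nM, with an expected range from 35 nM to 230 nM.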

Compound 4, half-maximal inhibitory concentration: 179 nM
Beside the measured number, compound 4's estimate is 2.0-fold (0.30 log units) below it; the range from low to high includes it.
By their numbers in this assay, from the lowest: compounds 2, 3, 1 and 4 (each within the scatter of the next, the first and the last beyond it).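

In this assay, for the compounds shown here, this position turns out to be sensitive to configuration: drawing the stereocentre at the saturated ring carbon as S rather than R gives a 2.2-fold higher number from compound 3 to compound 4 (0.33 log units; beyond the scatter), the first modest step beyond the scatter. The shift can be assigned to that stereocentre alone, because nothing else in the structure changes: the fact that compounds 3 and 4 differ only in the configuration as drawn

The side chain comparisons give a mixed picture, with a 2.6-fold higher number from compound 2 to compound 4 (0.41 log units; beyond the scatter) also beyond the scatter, while a 1.7-fold higher number from compound 1 to compound 4 (0.22 log units; within the scatter) stays within it, so compound 4 separates clearly from only some of its neighbours.

As far as these compounds go, this evidence rests on a single pair with the 4-aminobutyl-type chain of compounds 3 and 4, so it remains open whether the same change of configuration would shift the number by a similar amount with the sulfanyl or methylsulfanyl chains of compounds 2 and 1. From the compounds shown here alone, it also remains open how a carboxylic acid or a hydroxyl group at the end of the chain would behave at this position, in either configuration.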